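Replacing a nitrile with an amide on the distal ring

The source may report more compounds than this note shows. Statements on the series, on what has been measured and on what is new or still open speak of the compounds shown alone.

Of the compounds shown here, three sharing one core have been measured in an assay on isolated protein for inhibition of 2-Hydroxyacid oxidase 2 (Homo sapiens), tested at 10 uM; on this read-out higher numbers stand for a stronger effect at the one concentration tested and lower numbers for a weaker effect. Compound 1 `Cc1n[nH]c(C(=O)O)c1Cc1cccc(-c2cccc(F)c2)c1` gives 50%. Compound 2 `Cc1n[nH]c(C(=O)O)c1Cc1cccc(C(F)(F)F)c1` gives 23%, and compound 3 `Cc1n[nH]c(C(=O)O)c1Cc1cccc(-c2ccc(C#N)cc2)c1` gives 46%. On these numbers compound 3 stands second highest of the three, with compound 1 close by and compound 2 further off; the step of a number 23 percentage points higher from compound 2 to compound 3 (beyond the scatter) is beyond the scatter, while the step of a number 4 percentage points lower from compound 1 to compound 3 (within the scatter) is within it.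

Compound 4 `Cc1n[nH]c(C(=O)O)c1Cc1cccc(-c2ccc(C(N)=O)cc2)c1` differs from compound 3 in one place: carbamoyl in place of cyano on an aromatic carbon. Going by the values given here, no measured step swaps cyano for carbamoyl, so nothing directly bears on it. The nearest hint is the step of a number 4 percentage points lower from compound 1 to compound 3 (within the scatter), where a change at the same place, on the six-membered aromatic ring of carbon only, stayed within the scatter. The step of a number 27 percentage points lower from compound 1 to compound 2 (beyond the scatter) concerns removal of that ring and is less relevant. A step of about a number 1 percentage points lower from compound 3 to compound 4 (within the scatter) in this assay is therefore expected, that is none beyond the scatter. Compound 4 is estimated at 45%, with a range from 25% to 65%.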

Compound 4, a percentage reported as inhibition, at one concentration (the size of the read-out at that concentration, not a potency): 60%
Beside the measured number, compound 4's estimate is 15 percentage points below it, and the stated range covers the measured number.
By their numbers in this assay, from the lowest: compound 2; then compounds 3, 1 and 4 (each within the scatter of the next, the first and the last beyond it).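

In this assay, carbamoyl in place of cyano gives a number 14 percentage points higher from compound 3 to compound 4 (beyond the scatter). This shows that a change at this place, para to a large group, can move the read-out beyond the scatter, which the swap of 3-fluorophenyl for 4-cyanophenyl, a number 4 percentage points lower from compound 1 to compound 3 (within the scatter), did not show. Carbamoyl brings a hydrogen-bond donor that cyano lacks and one more heavy atom, but nothing available explains the gain or separates these two differences.

On these data alone, whether the donor matters therefore stays open; an amide with a methyl on its nitrogen, a carboxylic acid or an aminomethyl group at this place would extend the comparison. The read-out also comes from one concentration, so this step leaves the difference in potency between the two compounds unknown.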